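Swapping a Pyrimidine for a Triazole on the Amide Aryl

The compounds below may be only part of what the source reports. "The series", "measured", "known", "first", "only" and "open" are said of these compounds alone.

Compound 1 `Cc1ccc(-c2ncccn2)c(C(=O)N2CCC3(CC3)C[C@H]2CNc2ccc(Cl)cn2)c1`: 7.6
Compound 2 `N#Cc1ccc(-c2ncccn2)c(C(=O)N2CC3(CC3)C[C@H]2CNc2ccc(C(F)(F)F)cn2)c1`: 8
Compound 3 `O=C(c1ncccc1-c1ncccn1)N1CC2(CC2)C[C@H]1CNc1ccc(C(F)(F)F)cn1`: 7.7

These three compounds were measured in a functional assay on CHO cells for antagonist activity at Orexin/Hypocretin receptor type 1 (Homo sapiens), read by FLIPR and calcium flux; a higher number here means a more potent compound, by a factor of ten per unit of this negative logarithm, a lower number a less potent compound. Compound 1 sits at the low end of the three: the value of compound 3 lies within the usual scatter of it, whereas compound 2 stands beyond the scatter above it.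

Compound 4 `Cc1ccc(-n2nccn2)c(C(=O)N2CCC3(CC3)C[C@H]2CNc2ccc(Cl)cn2)c1` is not yet measured. It differs from compound 1 in one place: 2H-1,2,3-triazol-2-yl in place of pyrimidin-2-yl on an aromatic carbon. Going by the values given here, no measured pair in this set shows the same change, so there is no direct step to lean on. The change is small and keeps the ring aromatic, so the expectation is a step of a number 0.20 log units higher from compound 1 to compound 4 (within the scatter) of modest size, if any, and not clearly beyond the scatter. Compound 4 is therefore expected to give about 7.8 in this assay, estimated between 7.2 and 8.4.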

Compound 4, negative logarithm of the antagonist equilibrium constant: 7.5
For compound 4 the middle estimate is 0.30 log units above the measured one; low and high end bracket the measured number.
By their numbers in this assay, from the lowest: compounds 4, 1, 3 and 2 (each within the scatter of the next, the first and the last beyond it).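

In this assay, 2H-1,2,3-triazol-2-yl in place of pyrimidin-2-yl gives a number 0.10 log units lower from compound 1 to compound 4 (within the scatter) and so no readable change in potency. On this aromatic carbon, ortho to a large group, a five-membered aromatic ring with 3 hetero atoms thus reads the same as a six-membered one with 2. Nothing at hand explains this match. Going by these compounds, what a phenyl ring, an amine or a carboxylic acid would do on this carbon stays open. So does whether the same swap would give a similar step on the core of compound 2.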